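The compounds below may be only part of what the source reports. "The series", "measured", "known", "first", "only" and "open" are said of these compounds alone.

Measured compounds:
- compound 1, `CCOc1ccc(-c2ccc3ncn(-c4cc(OC)c(OC)c(OC)c4)c3c2)cc1`: 2970 nM
- compound 2, `COc1ccc(-c2ccc3ncn(-c4cc(OC)c(OC)c(OC)c4)c3c2)cc1O`: 44 nM
- compound 3, `COc1ccc(-c2ccc3ncn(-c4cc(OC)c(OC)c(OC)c4)c3c2)cc1F`: 430 nM

All three share one core and differ only in the ring attached to it. In a functional assay on SGC-7901 cells (Homo sapiens) for antiproliferative activity, read by MTT assay, with a stated time of 72 h (a lower number here means a stronger inhibitor, a higher number a weaker inhibitor), compound 1 gives the highest of the three numbers, so it is the weakest inhibitor of the set; compound 3 sits nearest to it and compound 2 furthest away. The unmeasured compound 4, `COc1cc(-n2cnc3ccc(-c4cccc(O)c4)cc32)cc(OC)c1OC`, is reached from compound 1 by one change: 3-hydroxyphenyl in place of 4-ethoxyphenyl on an aromatic carbon. The new group sits on an aromatic carbon of a six-membered aromatic ring of carbon only, part of a fused or bridged system of two rings.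

Among the measured compounds shown here, two measured steps bear on this. The move a 68-fold lower number from compound 1 to compound 2 (1.83 log units; beyond the scatter) shows that bringing in a 3-hydroxy-4-methoxyphenyl in place of 4-ethoxyphenyl gives a large gain. The move a 6.9-fold lower number from compound 1 to compound 3 (0.84 log units; beyond the scatter) shows that a 3-fluoro-4-methoxyphenyl gives a smaller gain, and a 9.8-fold higher number from compound 2 to compound 3 (0.99 log units; beyond the scatter) separates the hydroxy from the fluoro. For the measured compounds named here, compound 4 carries the hydroxy but no methoxy, and no measured pair tests the methoxy alone, so the gain is expected to be smaller than for compound 2. Compound 4 is therefore estimated at 200 nM, within 40 nM to 1000 nM, an expected step of a 15-fold lower number from compound 1 to compound 4 (1.17 log units; beyond the scatter).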

Compound 4, half-maximal inhibitory concentration: 53 nM
Compound 4: middle estimate off by 3.8-fold (0.58 log units), on the high side, and the stated range covers the measured number.
By their numbers in this assay, from the lowest: compounds 2 and 4 (each within the scatter of the next); then compound 3; then compound 1.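

In this assay, hydrogen in place of methoxy gives a 1.2-fold higher number from compound 2 to compound 4 (0.08 log units; within the scatter), so at this position the methoxy group of compound 2 makes no difference that can be seen. The 3-hydroxyphenyl group without that methoxy keeps the large gain, showing a 56-fold lower number from compound 1 to compound 4 (1.75 log units; beyond the scatter) when it replaces 4-ethoxyphenyl and an 8.1-fold lower number from compound 3 to compound 4 (0.91 log units; beyond the scatter) when it replaces 3-fluoro-4-methoxyphenyl, so the hydroxy group goes with the low numbers here, while the methoxy does not need to be present. Nothing measured here explains why the hydroxy group has this link to the lower numbers.

The compounds shown leave open how much of the gain over compound 1 comes from adding the hydroxy group and how much from losing the ethoxy group, a question that plain phenyl and 4-methoxyphenyl at this position could help to separate. From the compounds shown here alone, it also remains open whether another group could stand in for the hydroxy, such as the amine of 3-aminophenyl or the carboxylic acid of 3-carboxyphenyl.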